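The source may hold more compounds than are shown below. What is called first, only, known or untested is meant among the compounds shown, and "the series" means these compounds.

Series notes. In an ADME assay on NHDF cells (Homo sapiens) for cytotoxicity, read by MTT assay, with a stated time of 72 h (on this read-out higher numbers stand for weaker inhibition and lower numbers for stronger inhibition), compound 1 `COc1cccc(/C=C2\CCC/C(=C\c3ccccc3Cl)C2=O)c1OC` gives 44200 nM. Compound 2 `COc1cccc(/C=C2\CCC/C(=C\c3ccc(Cl)cc3)C2=O)c1OC` gives 18600 nM, with a 2.4-fold lower number from compound 1 to compound 2 (0.38 log units; beyond the scatter). For compound 3 `COc1cccc(/C=C2\CCC/C(=C\c3ccccc3Br)C2=O)c1OC` the assay reports only a limit, > 50000 nM, which is the limit of > 50000 nM in this assay, at which 1 of the 3 values shown sits; compound 3 is thus known only to that limit and not as a number. Compound 4 `COc1ccc(/C=C2\CCC/C(=C\c3cccc(OC)c3OC)C2=O)cc1` is unmeasured; it differs from compound 3 by 4-methoxyphenyl in place of 2-bromophenyl on a double-bonded chain carbon bound to a double-bonded ring carbon. Bearing on this change are an at least 2.6-fold higher number from compound 2 to compound 3 (0.42 log units; beyond the scatter) and a 2.4-fold lower number from compound 1 to compound 2 (0.38 log units; beyond the scatter); in both, 4-chlorophenyl gave the lower number. Among the measured compounds shown here, a modest lowering in this assay is therefore expected, though methoxy in place of chloro is covered by no measured pair. The expected step is an at least 2.0-fold lower number from compound 3 to compound 4 (0.30 log units; that floor lies within the scatter). Compound 4 is estimated at 25000 nM, between 10000 nM and 60000 nM.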

Compound 4, half-maximal inhibitory concentration: 43500 nM
Compound 4: middle estimate off by 1.7-fold (0.24 log units), on the low side, within the range that was stated.
By their numbers in this assay, from the lowest: compound 2; then compounds 4 and 1 (each within the scatter of the next). At a limit, above all of these: compound 3.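

In this assay, the lower number of compound 2 does not carry over to 4-methoxyphenyl at this place: a 2.3-fold higher number from compound 2 to compound 4 (0.37 log units; beyond the scatter). So a group in the 4 position of this phenyl does not by itself give the lower number, and 4-methoxyphenyl is not separated from 2-chlorophenyl: a 1.0-fold lower number from compound 1 to compound 4 (0.01 log units; within the scatter). The step out of the limit held by compound 3 is only a floor: an at least 1.1-fold lower number from compound 3 to compound 4 (0.06 log units; that floor lies within the scatter).

From the compounds shown here alone, whether the lower number of compound 2 is specific to chloro remains open. An amine or a carboxylic acid on this phenyl would test that.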